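Melanocortin receptor 4 binding: the anilinomethyl amide, compound 4

This account rests on a few compounds, and the source may have more. Where it says the series, first, only, none or still open, it means among the compounds named here.

Measured so far in an assay on HEK293 cells for displacement of a labelled ligand from Melanocortin receptor 4 (Homo sapiens); on this read-out higher numbers stand for weaker inhibition and lower numbers for stronger inhibition:
- compound 1 `CC(C)C[C@H](N)c1cc(C(F)(F)F)ccc1N1CCN(C(=O)C(C)Cc2ccc(Cl)cc2O)CC1`: 36 nM
- compound 2 `COc1cc(Cl)ccc1C[C@@H](C)C(=O)N1CCN(c2ccc(C)cc2[C@@H](N)CC(C)C)CC1`: 8.1 nM
- compound 3 `Cc1ccc(N2CCN(C(=O)[C@H](C)Cc3ccc(Cl)cc3F)CC2)c([C@@H](N)CC(C)C)c1`: 20 nM

Compound 1 gives the highest number of the three; compound 3 lies within the scatter of it, compound 2 beyond it. Going by the values given here, the only step between two measured compounds is a 2.5-fold higher number from compound 2 to compound 3 (0.39 log units; beyond the scatter), which concerns the ring carried by the amide side chain and leaves the rest of the shared core untouched.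

Compound 4 `CC(C)C[C@H](N)c1cc(C(F)(F)F)ccc1N1CCN(C(=O)CNc2ccccc2)CC1` is not yet measured. Its change from compound 1 is anilinomethyl in place of 1-(4-chloro-2-hydroxybenzyl)ethyl on a carbonyl carbon. Among the compounds with values here, no measured step concerns this part of the structure: the one step seen alters a single substituent on that ring, whereas here the whole 1-(4-chloro-2-hydroxybenzyl)ethyl group, chlorine, hydroxyl and methyl branch included, is exchanged for anilinomethyl, a shorter group with a nitrogen in place of the branched carbon chain. The step of compound 2 to compound 3 shows that even a small alteration on this ring moves the number beyond the scatter, so a larger alteration is expected to move it further, towards a higher number. Compound 4 is therefore estimated at 200 nM in this assay, between 60 nM and 800 nM, meaning an expected step of a 5.6-fold higher number from compound 1 to compound 4 (0.74 log units; beyond the scatter).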

Compound 4, inhibition constant: 3600 nM
Beside the measured number, compound 4's estimate is 18-fold (1.26 log units) below it; the measured number lies above the stated range.
By their numbers in this assay, from the lowest: compound 2; then compounds 3 and 1 (each within the scatter of the next); then compound 4.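

In this assay, going by these compounds alone, the exchange of 1-(4-chloro-2-hydroxybenzyl)ethyl for anilinomethyl on the carbonyl carbon gives a 100-fold higher number from compound 1 to compound 4 (2.00 log units; beyond the scatter), a much larger step than the single ring substituent change, a 2.5-fold higher number from compound 2 to compound 3 (0.39 log units; beyond the scatter). The two groups match in their aromatic ring, hydrogen-bond donor and acceptor counts and net charge, so matching these counts does not preserve the number at this position. Nothing available explains the size of the step.

The exchange alters the chlorine, the hydroxyl, the methyl branch and the chain nitrogen together, so the compounds shown do not separate their contributions. On these data alone, it remains open whether an all-carbon 2-phenylethyl group, or anilinomethyl with chlorine and hydroxyl on its ring, would recover the lower numbers on the same carbonyl carbon.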